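Notes: dimethylamino in place of methyl on compound 2

The compounds below may be only part of what the source reports. "The series", "measured", "known", "first", "only" and "open" are said of these compounds alone.

Compound 1 `COc1cccc(-c2nc3ccc(N4CCCCC4)cc3c(=O)[nH]2)c1OC`: 10400 nM
Compound 2 `Cc1ccc2c(=O)[nH]c(-c3ccccc3C)nc2c1`: > 50000 nM (a limit of the assay)

Both compounds were read in a functional assay on T47D cells (Homo sapiens) for cytotoxicity, read by MTT assay, with a stated time of 2 days; on this read-out higher numbers stand for weaker inhibition and lower numbers for stronger inhibition. Going by the values given here, compound 1 is the only one with a measured number so far. Compound 2 reads > 50000 nM, which is a limit of the assay and not a number. The position in the series is therefore only this: the limit of > 50000 nM in this assay, at which 1 of the 2 values shown sits.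

Compound 3 `Cc1ccc2c(=O)[nH]c(-c3ccccc3N(C)C)nc2c1` differs from compound 2 in one place, on an aromatic carbon of a six-membered aromatic ring of carbon only, ortho to a large group. There, dimethylamino stands in place of methyl: dimethylamino in place of methyl on an aromatic carbon. Among the compounds with values here, no measured step covers this change, and the expectation is loose.

A small move toward stronger inhibition in this assay is expected, or none beyond the scatter, and an at least 1.4-fold lower number from compound 2 to compound 3 (0.15 log units; that floor lies within the scatter) is the estimated size. Compound 1 gives 10400 nM, and compound 3 is expected to remain weaker than that value. For compound 3 the estimated value is 35000 nM, with an expected range from 12000 nM to 70000 nM.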

Compound 3, half-maximal inhibitory concentration: 4430 nM
The estimate for compound 3 lay 7.9-fold (0.90 log units) above the measured number; measured number outside the range, below it.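

On an aromatic carbon of a six-membered aromatic ring of carbon only, ortho to a large group, the series now has its first one-place change read in this assay: dimethylamino in place of methyl gives an at least 11-fold lower number from compound 2 to compound 3 (1.05 log units; beyond the scatter). The step is beyond the usual scatter, so the group at this position matters for the read-out, and the shared core alone does not set the level, with compound 3 at 4430 nM. Compound 2 reads > 50000 nM, which is a limit of the assay and not a number, so the step has a floor but no known full size: the limit of > 50000 nM in this assay, at which 1 of the 3 values shown sits.

Going by these compounds alone, the single step swaps methyl for dimethylamino, so it leaves open whether the nitrogen or the larger size of the entering group goes with the lower number. An isopropyl group and a primary amine on the same aromatic carbon would pull those two apart, and a measured value for a close analogue of compound 2 would give the step a full size.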